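The compounds below may be only part of what the source reports. "The series", "measured", "known", "first", "only" and "open" are said of these compounds alone.

Working notes on the series.

Compound 1 `CC[C@H](C)[C@H](NC(=O)CN(c1ncnc2c1ncn2C1CCCCO1)C1CC1)C(=O)OCc1ccccc1`, compound 2 `NC(=O)C[C@H](NC(=O)CN(c1ncnc2c1ncn2C1CCCCO1)C1CC1)C(=O)OCc1ccccc1` and compound 3 `CCOC(=O)CN(c1nc(Cl)nc2c1ncn2C1CCCCO1)C1CC1` share one core. In a functional assay on the whole organism (Tail, strain ICR) with Mus musculus as the target, in the tail flick test, with a stated time of 60 min, at a dose of 25 umol/kg by the oral route (on this read-out lower numbers stand for a weaker effect and higher numbers for a stronger effect at the one dose given), compound 1 gives 27.4%, compound 2 gives 30.5% and compound 3 gives 22.6%. Compound 2 holds the highest of the three numbers, yet its gaps to compound 1 and to compound 3 both lie within the scatter, so no order among the three can be read. Among the measured compounds shown here, the one step with a single point of change is a number 3.1 percentage points higher from compound 1 to compound 2 (within the scatter).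

Compound 4 `CSCC[C@H](NC(=O)CN(c1ncnc2c1ncn2C1CCCCO1)C1CC1)C(=O)OCc1ccccc1` is not yet measured. Its difference from compound 2 is (methylsulfanyl)methyl in place of carbamoyl on a saturated chain carbon, two bonds along the chain from an amide-type nitrogen and a carbonyl carbon. The step from compound 1 to compound 2 bears on it most closely: it exchanged one side chain on the same carbon for another, and in this assay it stayed within the scatter. For the measured compounds named here, no step touching a sulfur-bearing chain is available. For compound 4 in this assay an expected step of a number 2.5 percentage points lower from compound 2 to compound 4 (within the scatter) is therefore assumed, that is no movement beyond the scatter. The estimate for compound 4 in this assay is 28%, expected between 15% and 42%.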

Compound 4, a percentage reported as activity, at one dose (the size of the read-out at that dose, not a potency): 41%
Beside the measured number, compound 4's estimate is 13 percentage points below it; the range from low to high includes it.
By their numbers in this assay, from the lowest: compounds 3, 1 and 2 (each within the scatter of the next); then compound 4.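

In this assay the side chain on this carbon proves able to move the read-out: (methylsulfanyl)methyl in place of carbamoyl gives a number 10.5 percentage points higher from compound 2 to compound 4 (beyond the scatter) and 2-(methylsulfanyl)ethyl in place of sec-butyl gives a number 13.6 percentage points higher from compound 1 to compound 4 (beyond the scatter) on the same carbon. Among the compounds shown here, the earlier exchange on this carbon, carbamoylmethyl in place of sec-butyl, gave only a number 3.1 percentage points higher from compound 1 to compound 2 (within the scatter) so the sulfur-bearing chain is the first change here to pass the scatter, though both of its steps are modest in size. Nothing available explains why this chain stands apart.

From the compounds shown here alone, whether the sulfur itself matters stays open, since an all-carbon n-butyl chain, or the sulfoxide or sulfone of the same chain, would separate it from chain length. Also open, going by these compounds, is how a longer thioether chain, an amine or a carboxylic acid at this carbon would read.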